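The compounds below may be only part of what the source reports. "The series", "measured", "known", "first", "only" and "open" are said of these compounds alone.

Measured so far:
Compound 1, `COc1ccc(C)cc1NC(=S)N/N=C/c1ccc2ccccc2n1`: in a functional assay on HT-29 cells (Homo sapiens) for antiproliferative activity, read by sulforhodamine B assay, with a stated time of 72 h (on this read-out higher numbers stand for weaker inhibition and lower numbers for stronger inhibition), compound 1 gives > 100000 nM, which is a limit of the assay and not a number.
Compound 2, `Cc1cccc(NC(=S)N/N=C/c2ccc3ccccc3n2)c1`: in this assay compound 2 gives > 100000 nM, again a limit rather than a number.
Compound 3, `NC(=S)N/N=C/c1ccc2cccnc2n1`: in this assay compound 3 gives 12800 nM.

Compound 2 thus stands at the limit, one of the two values that sit there (the limit of > 100000 nM in this assay, at which 2 of the 3 values shown sit), so all that is known of it is that its inhibition is weak. Within the data shown here, compound 3, with a different core and no aryl group on the thiourea nitrogen, gives a number, but no step connects it to compound 2. Among the measured compounds shown here, the only measured step, a step that the two limits leave unreadable from compound 1 to compound 2, runs from one limit to another and cannot be read in size or direction.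

Compound 4, `Cc1ccccc1NC(=S)N/N=C/c1ccc2ccccc2n1`, differs from compound 2 by 2-methylphenyl in place of 3-methylphenyl on an amide-type nitrogen. For the measured compounds named here, no measured step bears on this change. Given that compound 2 gives > 100000 nM, the expected step of a number no higher from compound 2 to compound 4 (the limit leaves the size open) is none beyond the scatter. Compound 4 is therefore estimated at 100000 nM, with a range from 30000 nM to 300000 nM, most likely reported again as a limit.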

Compound 4, half-maximal inhibitory concentration: 42300 nM
Compound 4: the middle estimate sits 2.4-fold (0.37 log units) above what was measured; low and high end bracket the measured number.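

In this assay, 2-methylphenyl in place of 3-methylphenyl on an amide-type nitrogen gives an at least 2.3-fold lower number from compound 2 to compound 4 (0.37 log units; beyond the scatter). Among these compounds, this is the first step in the set that can be read: the two compounds hold the same atoms, joined differently, and that alone is enough to turn a limit into a measured number. How large the step really is stays unknown because compound 2 is known only as a limit: the limit of > 100000 nM in this assay, at which 2 of the 4 values shown sit.

From the compounds shown here alone, whether an amine or a carboxylic acid in place of the methyl group on this phenyl ring would give a lower number remains open, as does the effect of a longer chain there. Also open, going by these compounds, is whether 2-methylphenyl would bring a similar gain on the core of compound 3, which has no aryl group on that nitrogen.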